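The compounds below may be only part of what the source reports. "The series", "measured", "known", "first", "only" and "open" are said of these compounds alone.

Measured so far:
compound 1 `CC1CCN(C2CCN(S(=O)(=O)c3cccc(-c4ccccc4F)c3)CC2)CC1`: > 5000 nM
compound 2 `CC1CCN(C2CCN(S(=O)(=O)c3cc(F)c(Br)c(F)c3)CC2)CC1`: > 5000 nM

In an ADME assay on HCT-116 cells (Homo sapiens) for cytotoxicity, read by CellTiter-Glo, with a stated time of 72 h (a higher number here means a weaker inhibitor, a lower number a stronger inhibitor), compound 1 gives > 5000 nM, which is a limit of the assay rather than a number. In this assay compound 2 gives > 5000 nM, again a limit. Compound 1 therefore stands at the edge of what this assay reports, as the limit of > 5000 nM in this assay, at which 2 of the 2 values shown sit, shows. Compound 3 `CC1CCN(C2CCN(S(=O)(=O)c3cccc(-c4ccc5ccccc5c4)c3)CC2)CC1` differs from compound 1 by naphthalen-2-yl in place of 2-fluorophenyl on an aromatic carbon. Among the measured compounds shown here, no step between measured compounds is available here, so in this assay nothing beyond the scatter is expected. The estimated step is a step that the limit leaves unreadable from compound 1 to compound 3. Compound 3 is expected to give 8000 nM, within 3000 nM to 25000 nM, most probably again only a limit.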

Compound 3, half-maximal inhibitory concentration: > 5000 nM
Compound 3: a limit, no number; the forecaster's own chance of this, stated with the estimate: 80%; the middle value lies beyond the limit too.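

Among the compounds shown here, compound 1 and compound 3 both sit at a limit in this assay, so no step between them can be read: the limit of > 5000 nM in this assay, at which 3 of the 3 values shown sit. The compounds shown leave open how strongly any of them inhibits in this assay, and how naphthalen-2-yl compares with 2-fluorophenyl.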